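This account rests on a few compounds, and the source may have more. Where it says the series, first, only, none or still open, it means among the compounds named here.

Of the compounds shown here, three have been read in a functional assay on KYSE-410 cells (Homo sapiens) for antiproliferative activity, read by MTT assay, with a stated time of 72 h (on this read-out lower numbers stand for stronger inhibition and higher numbers for weaker inhibition), and none of them gives a number. Compound 1 (`O=C(Nc1ccc(F)cc1)c1ccnc2cc(Br)ccc12`) reads > 20000 nM, which is a limit. Compound 2 (`O=C(Nc1cccc(C(F)(F)F)c1)c1cc(=O)[nH]c2cc(Br)ccc12`) reads > 20000 nM, which is also a limit. Compound 3 (`CC(=O)c1ccc(-c2ccc3c(C(=O)Nc4cccc(F)c4)cc(=O)[nH]c3c2)cc1`) reads > 20000 nM, again a limit, so its position in the set is known only as a limit. The whole set comes down to one entry: the limit of > 20000 nM in this assay, at which 3 of the 3 values shown sit.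

Compound 4 (`O=C(Nc1cccc(F)c1)c1cc(=O)[nH]c2cc(-c3ccncc3)ccc12`) has not yet been measured. It carries pyridin-4-yl in place of 4-acetylphenyl on an aromatic carbon of compound 3: pyridin-4-yl in place of 4-acetylphenyl on an aromatic carbon. Among the compounds with values here, the series holds no measured step between compounds that differ in one place, so the size of a change at this carbon in this assay has no direct precedent.

The expectation starts from compound 3 at > 20000 nM, a limit, and allows for no step beyond the scatter, with any movement more likely towards stronger inhibition. The expected change is an at least 1.1-fold lower number from compound 3 to compound 4 (0.04 log units; that floor lies within the scatter). The estimate for compound 4 is 18000 nM, with an expected range of 7000 nM to 30000 nM. A report of a limit alone, with no number, remains the likelier result.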

Compound 4, half-maximal inhibitory concentration: > 20000 nM
Compound 4: no number, only a limit (the forecaster's own chance of this, stated with the estimate: 70%); at least 1.1-fold (0.04 log units) between middle value and limit.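

In this assay compound 4 gives > 20000 nM, which is a limit. Compound 3 also stands at a limit, so no step can be read between compound 3 and compound 4. The compounds shown leave open which change to the shared core, if any, would give a number rather than a limit: the limit of > 20000 nM in this assay, at which 4 of the 4 values shown sit.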